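Bromo in Place of Fluoro at the Assay Limit

This account rests on a few compounds, and the source may have more. Where it says the series, first, only, none or still open, it means among the compounds named here.

Compound 2 `C/C(=N\Nc1nc(-c2ccc(F)cc2)cs1)c1sc(-c2ccccc2)nc1C`, measured in a toxicity assay on THP-1 cells (Homo sapiens) for cytotoxicity, read by MTT assay (on this read-out higher numbers stand for weaker inhibition of growth and lower numbers for stronger inhibition of growth), gives only a limit of the assay, > 100 ug/mL. Compound 1 `C/C(=N\Nc1nc(-c2ccc(Br)cc2)cs1)c1sc(C)nc1C` likewise gives a limit in this assay, > 100 ug/mL. Both results sit at the limit of > 100 ug/mL in this assay, at which 2 of the 2 values shown sit. Compound 3 `C/C(=N\Nc1nc(-c2ccc(Br)cc2)cs1)c1sc(-c2ccccc2)nc1C` differs from compound 2 by bromo in place of fluoro on an aromatic carbon. Going by the values given here, no measured step exists between two compounds here, so the expected step that the limit leaves unreadable from compound 2 to compound 3 is no larger than the scatter, in no firm direction. Compound 3 is therefore estimated at 150 ug/mL, within 60 ug/mL to 400 ug/mL, and most probably reported again only as a limit.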

Compound 3, concentration for 50% growth inhibition: 48.9 ug/mL
The estimate for compound 3 lay 3.1-fold (0.49 log units) above the measured number, and the stated range ends above it.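

In this assay, compound 3 shows that this place, para to a large group, can move the read-out: bromo in place of fluoro gives an at least 2.0-fold lower number from compound 2 to compound 3 (0.31 log units; beyond the scatter). With bromo held fixed, phenyl in place of methyl gives an at least 2.0-fold lower number from compound 1 to compound 3 (0.31 log units; beyond the scatter), so neither change alone accounts for the result. Both steps start from a limit, so their full size cannot be read: the limit of > 100 ug/mL in this assay, at which 2 of the 3 values shown sit.

On these data alone, what chloro or an amine would give at this place stays open. So does how far compound 1 and compound 2 truly lie from compound 3.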